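Chain Shortening in Nitroindole Carboxylic Acids and Pannexin-1 Inhibition

This account rests on a few compounds, and the source may have more. Where it says the series, first, only, none or still open, it means among the compounds named here.

Measured compounds:
compound 1 `O=C(O)c1cc2cc([N+](=O)[O-])ccc2n1CCCc1ccccc1`, 65.5%;
compound 2 `O=C(O)c1cn(CCCCCc2ccccc2)c2ccc([N+](=O)[O-])cc12`, 32.3%;
compound 3 `O=C(O)c1cc2cc([N+](=O)[O-])ccc2n1Cc1ccccc1`, 51.3%.

In an assay on cells (Oocyte) for inhibition of pannexin-1 (Mus musculus), read by voltage clamp, tested at 50 uM, in the presence of a further agent that is not named here (a lower number here means less inhibition, a higher number more inhibition at the concentration tested (going by the name of the read-out)), compound 1 gives 65.5% and compound 3 gives 51.3%. The change between them is phenyl in place of phenethyl on a saturated chain carbon bound to an aromatic nitrogen, and the step was a number 14.2 percentage points lower from compound 1 to compound 3 (beyond the scatter). Compound 2 gives 32.3%, the lowest of the three; the difference between the cores of compound 1 and compound 2 is not broken down here. Compound 4 `O=C(O)c1cn(CCCc2ccccc2)c2ccc([N+](=O)[O-])cc12` has not been measured. It differs from compound 2 by phenyl in place of phenethyl on a saturated chain carbon, three bonds along the chain from an aromatic nitrogen, the same kind of change, though here the saturated chain carbon is three bonds along the chain from the aromatic nitrogen rather than bound to it. Because the step of a number 14.2 percentage points lower from compound 1 to compound 3 (beyond the scatter) went lower, compound 4 is expected to fall further, with an estimated step of a number 10.3 percentage points lower from compound 2 to compound 4 (beyond the scatter). The estimate for compound 4 is 22%, expected between 5% and 42%.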

Compound 4, a percentage reported as inhibition, at one concentration (the size of the read-out at that concentration, not a potency): 71%
Estimate against measurement, compound 4: 49 percentage points below; measured number outside the range, above it.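

In this assay, phenyl in place of phenethyl gave a number 38.7 percentage points higher from compound 2 to compound 4 (beyond the scatter), so the fall seen on the core of compound 1 did not carry over to the core of compound 2. The same change thus moved the two cores in opposite directions: the same change on two cores in this assay, a number 14.2 percentage points lower (beyond the scatter) from compound 1 to compound 3 and a number 38.7 percentage points higher (beyond the scatter) from compound 2 to compound 4, 52.9 percentage points apart, beyond the scatter of two such steps This shows that a step measured on one core cannot be transferred to the other in this series, but it does not show why the two differ, and one pair on each core gives no general rule.

The compounds shown leave open whether this opposite behaviour holds for a longer chain than that of compound 2. They also leave open whether an amide in place of the carboxylic acid would behave the same way on either core.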